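Moving the Chlorine Around the Ring: Compound 3

The source may hold more compounds than are shown below. What is called first, only, known or untested is meant among the compounds shown, and "the series" means these compounds.

Of the compounds shown here, two sharing one core have been measured in an ADME assay on HEK293 cells (Homo sapiens) for cytotoxicity, read by CCK-8 assay and cell counting, with a stated time of 2 days; a lower number here means a stronger inhibitor, a higher number a weaker inhibitor. Compound 1 `Oc1cccc(-c2cc(-c3ccccc3)nc(-c3ccccc3Cl)c2)c1` gives 1760 nM in this assay. Compound 2 `Oc1cccc(-c2cc(-c3ccccc3)nc(-c3ccc(Cl)cc3)c2)c1` gives 11600 nM in this assay. Among the measured compounds shown here, compound 2 therefore stands with the higher of the two numbers; its only neighbour is compound 1, and the step of a 6.6-fold higher number from compound 1 to compound 2 (0.82 log units; beyond the scatter) lies beyond the usual scatter, so compound 2 is the weaker of the pair in this assay.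

Compound 3 `Oc1cccc(-c2cc(-c3ccccc3)nc(-c3cccc(Cl)c3)c2)c1` is not yet measured. It differs from compound 2 by 3-chlorophenyl in place of 4-chlorophenyl on an aromatic carbon. For the measured compounds named here, the single measured step that bears on this change is a 6.6-fold higher number from compound 1 to compound 2 (0.82 log units; beyond the scatter), which shows that where the chlorine sits on that ring can move the number by a modest amount. Compound 3 carries its chlorine at a place covered by neither measured compound, so the direction is uncertain; the expectation is a number lying between those of compound 1 and compound 2, that is an expected step of a 2.3-fold lower number from compound 2 to compound 3 (0.37 log units; beyond the scatter). For compound 3 in this assay the estimate is 5000 nM, with a range from 1500 nM to 16000 nM.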

Compound 3, half-maximal inhibitory concentration: 3120 nM
Compound 3: the middle estimate sits 1.6-fold (0.20 log units) above what was measured; low and high end bracket the measured number.
By their numbers in this assay, from the lowest: compounds 1 and 3 (each within the scatter of the next); then compound 2.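

In this assay, moving the chlorine from the 4-chlorophenyl group of compound 2 to the 3-chlorophenyl group gives a 3.7-fold lower number from compound 2 to compound 3 (0.57 log units; beyond the scatter) and so shows that this shift alone, with the same atoms joined differently, can carry the number beyond the scatter. The other new comparison, a 1.8-fold higher number from compound 1 to compound 3 (0.25 log units; within the scatter), stays within the scatter, so the 2-chlorophenyl and 3-chlorophenyl groups cannot be told apart here, and the earlier gap between compound 1 and compound 2 now reads as compound 2 standing apart from both, as the weakest of the three. Nothing on hand explains why the 4-chlorophenyl group stands apart in this way.

All three compounds carry a single chlorine on this ring, so the compounds shown leave open whether the same order of positions would hold for a different substituent, such as a methoxy group, an amine or a carboxylic acid. They also leave open how the number would respond to changes elsewhere on the shared core, for instance to the 3-hydroxyphenyl group or the phenyl group.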